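Cyclopropylmethyl for 3-fluorophenyl at the hydroxy-bearing carbon

The source may report more compounds than this note shows. Statements on the series, on what has been measured and on what is new or still open speak of the compounds shown alone.

Of the compounds shown here, three sharing one core have been measured in an ADME assay on liver for metabolic stability, with Liver microsome (Homo sapiens) as the target, read by LC-MS, using microsomes; on this read-out higher numbers stand for fast clearance and lower numbers for slow clearance. Compound 1 `CC1(C[C@@H](O)C(=O)N2C[C@H]3C[C@H]3[C@H]2C(=O)NCc2cc(Cl)ccc2-n2cnnn2)CC1` carries a saturated side chain on the hydroxy acyl group and in this assay gives 12 mL.min-1.g-1. Compound 2 `O=C(NCc1cc(Cl)ccc1-n1cnnn1)[C@@H]1C[C@H]2C[C@H]2N1C(=O)[C@H](O)c1cccc(F)c1` bears a 3-fluorophenyl at the same position and in this assay gives 32 mL.min-1.g-1, the highest of the two numbers, with compound 1 as its nearest neighbour at a gap beyond the usual scatter. Compound 3 `O=C(NCc1cc(Cl)ccc1-n1cnnn1)[C@@H]1C[C@@H]2C[C@@H]2N1C(=O)[C@H](O)c1cccc(Cl)c1` in this assay gives > 500 mL.min-1.g-1, which is a limit of the assay and not a number. That reading sits at the limit of > 500 mL.min-1.g-1 in this assay, at which 1 of the 3 values shown sits.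

Compound 4 `O=C(NCc1cc(Cl)ccc1-n1cnnn1)[C@@H]1C[C@H]2C[C@H]2N1C(=O)[C@H](O)CC1CC1` is not yet measured. It differs from compound 2 in one place: cyclopropylmethyl in place of 3-fluorophenyl on a saturated chain carbon bound to a carbonyl carbon and an oxygen on a saturated carbon. Within the data shown here, no measured pair shows this exact change, so the size of the step is uncertain. Compound 1, whose side chain is likewise a saturated carbon ring on a short chain, gives 12 mL.min-1.g-1 in this assay, a lower number than compound 2, and compound 4 is expected to fall in the same region. The step from compound 2 to compound 4 is therefore estimated as a 2.1-fold lower number from compound 2 to compound 4 (0.33 log units; beyond the scatter), toward slower clearance. Compound 4 is expected to give about 15 mL.min-1.g-1 in this assay, between 6 mL.min-1.g-1 and 40 mL.min-1.g-1.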

Compound 4, intrinsic clearance in microsomes: 25 mL.min-1.g-1
Estimate against measurement, compound 4: 1.7-fold (0.22 log units) below; the measured number falls inside the stated range.
By their numbers in this assay, from the lowest: compound 1; then compounds 4 and 2 (each within the scatter of the next). At a limit, above all of these: compound 3.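

In this assay, putting cyclopropylmethyl in place of 3-fluorophenyl on a saturated chain carbon bound to a carbonyl carbon and an oxygen on a saturated carbon gives a 1.3-fold lower number from compound 2 to compound 4 (0.11 log units; within the scatter) on the shared core. Among these compounds, the earlier compounds offered no pair differing in one place, so they could put no size on any exchange at this carbon; this pair is the first to do so, and its two members read alike within the usual scatter. In this single pair, then, the read-out does not depend on an aromatic ring at this carbon, since a three-membered non-aromatic ring of carbon only serves equally well, although this is one exchange on one core and supports no wider rule.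

From the compounds shown here alone, whether an amine or a carboxylic acid at this carbon, or a longer chain in place of cyclopropylmethyl, would also read alike in this assay remains open. Nothing in the data shown bears on why compound 2 and compound 4 read alike.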